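Ring Size at the Chain End: Pyrrolidine to Piperidine

The source may hold more compounds than are shown below. What is called first, only, known or untested is meant among the compounds shown, and "the series" means these compounds.

Measured so far:
compound 1, `CCCCc1sc(-c2ccc(Oc3ccc(Cl)cc3)cc2)nc1-c1ccc(OCC2CCCN(CC)C2)cc1`, 55.9%
compound 2, `CCCCc1sc(-c2ccc(OCCCN3CCCC3)cc2)nc1-c1ccc(Oc2ccc(Cl)cc2)cc1`, 47.8%

In an assay on isolated protein for antagonist activity at advanced glycosylation end product-specific receptor (Homo sapiens), read by ELISA, with a stated time of 60 min, tested at 10 uM (on this read-out lower numbers stand for less inhibition and higher numbers for more inhibition at the one concentration tested (going by the name of the read-out)), compound 1 gives 55.9%, and compound 2 gives 47.8%. Among the measured compounds shown here, compound 2 has the lower of the two numbers, but its only neighbour, compound 1, lies within the usual scatter of this assay, so the two cannot be put in order on this evidence. For the measured compounds named here, no pair of measured compounds differs in just one place, so there is no single-point step to lean on.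

Compound 3, `CCCCc1sc(-c2ccc(OCCCN3CCCCC3)cc2)nc1-c1ccc(Oc2ccc(Cl)cc2)cc1`, awaits measurement. Compared with compound 2 it carries this change: piperidin-1-yl in place of pyrrolidin-1-yl on a saturated chain carbon, three bonds along the chain from an oxygen on an aromatic ring. Nothing measured here speaks to such a change, so the expected step from compound 2 to compound 3 in this assay is a number 0.2 percentage points higher from compound 2 to compound 3 (within the scatter), that is, none beyond the scatter. Compound 3 is therefore expected to give about 48%, estimated to fall between 28% and 68%.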

Compound 3, a percentage reported as inhibition, at one concentration (the size of the read-out at that concentration, not a potency): 59.2%
For compound 3 the middle estimate is 11.2 percentage points below the measured one; measured number inside the range.
By their numbers in this assay, from the lowest: compounds 2, 1 and 3 (each within the scatter of the next, the first and the last beyond it).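

In this assay, among the compounds shown here, changing 3-(pyrrolidin-1-yl)propyl to 3-(piperidin-1-yl)propyl gives a number 11.4 percentage points higher from compound 2 to compound 3 (beyond the scatter), the first change in a single place that can be read in this set. The step is modest, but it shows that this position is not indifferent to the ring it carries: a six-membered non-aromatic ring gives a higher number here than a five-membered one. Nothing available explains why the number moves.

One step cannot show whether the trend would continue with a still larger ring such as azepan-1-yl. It also leaves open how a ring with a second hetero atom, such as morpholin-4-yl, or an open-chain diethylamino group would behave in this place.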